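Fluoro in place of methyl on the urea phenyl

The compounds below may be only part of what the source reports. "The series", "measured", "known", "first", "only" and "open" are said of these compounds alone.

Compound 2, `COc1ccc(-c2cnc3nc(N)nc(N4CCN(C(=O)Nc5ccc(C)cc5)CC4)c3n2)cc1OC`: in a functional assay on cells (T-cell, Homo sapiens) for inhibition (a lower number here means a stronger inhibitor, a higher number a weaker inhibitor), compound 2 gives 0.8 nM.
Compound 3, `COc1ccc(-c2cnc3nc(N)nc(NCc4cccs4)c3n2)cc1OC`: in this assay compound 3 gives 4100 nM.
Compound 1, `CCOc1nc(N)nc2ncc(-c3ccc(Cl)c(Cl)c3)nc12`: in this assay compound 1 gives > 10000 nM, which is a limit of the assay and not a number.

Among the two numbers shown, compound 2 stands lowest, and the nearest number, that of compound 3, lies far above it, well beyond the scatter of repeated measurements. Compound 1 sits at the limit of > 10000 nM in this assay, at which 1 of the 3 values shown sits.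

The step to follow here is a single, small one. Compound 4, `COc1ccc(-c2cnc3nc(N)nc(N4CCN(C(=O)Nc5ccc(F)cc5)CC4)c3n2)cc1OC`, keeps the whole of compound 2 except for one substituent on the outer phenyl ring of the urea: fluoro in place of methyl on an aromatic carbon. Among the compounds with values here, no measured pair in this set shows what such an exchange does, so the expectation rests only on its size. One heavy atom leaves and one enters, no ring, donor or acceptor changes, and no charge is touched. A step in this assay that stays within the scatter, in either direction, is the most plausible outcome, with a small weakening somewhat more likely than a gain. Compound 4 is therefore estimated at 1.5 nM, between 0.4 nM and 6 nM, which means an expected step of a 1.9-fold higher number from compound 2 to compound 4 (0.27 log units; within the scatter).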

Compound 4, half-maximal inhibitory concentration: 7 nM
For compound 4 the middle estimate is 4.7-fold (0.67 log units) below the measured one, and the stated range ends below it.
By their numbers in this assay, from the lowest: compound 2; then compound 4; then compound 3. At a limit, above all of these: compound 1.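

In this assay, fluoro in place of methyl on the outer phenyl ring of the urea gives an 8.8-fold higher number from compound 2 to compound 4 (0.94 log units; beyond the scatter). This is the only pair shown that differs in one place, and it reveals that the substituent at this position is not a neutral detail: one heavy atom is exchanged, the counts of rings, donors and acceptors stay the same, no charge is involved, and the step still lies beyond the usual scatter. The loss has a modest size, and compound 4 still gives a low number of 7 nM, but nothing measured here accounts for the step.

From the compounds shown here alone, a single exchange cannot separate what is lost with the methyl from what is brought in by the fluoro, so it remains open whether the 4-methylphenyl group is especially favourable or the 4-fluorophenyl group is unfavourable. An unsubstituted phenyl ring, or a chloro, ethyl or methoxy group at the same place, would show whether the number follows the size of the group or depends on something else.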